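Aryl for Alkyl on the Urea of Compound 2

This account rests on a few compounds, and the source may have more. Where it says the series, first, only, none or still open, it means among the compounds named here.

Measured compounds:
Compound 1 `CC(C)CN(CC(C)C)c1ccc(/C(=N/O)Nc2ccc(F)c(Br)c2)cc1NC(=O)NC1CCCCC1` — 1340 nM
Compound 2 `CCCCNC(=O)Nc1cc(/C(=N/O)Nc2ccc(F)c(Br)c2)ccc1N(CC(C)C)CC(C)C` — 3110 nM
Compound 3 `Cc1ccc(N/C(=N\O)c2ccc(N(CC(C)C)CC(C)C)c(NC(=O)Nc3cncnc3)c2)cc1` — 440 nM

In an assay on HeLa cells for inhibition of Indoleamine 2,3-dioxygenase 1 (Homo sapiens) (on this read-out higher numbers stand for weaker inhibition and lower numbers for stronger inhibition), compound 2 gives 3110 nM, the highest of the three numbers; compound 1 gives 1340 nM and compound 3 gives 440 nM. Compound 4 `CC(C)CN(CC(C)C)c1ccc(/C(=N/O)Nc2ccc(F)c(Br)c2)cc1NC(=O)Nc1ccc(C(F)(F)F)cc1` differs from compound 2 in one place: 4-(trifluoromethyl)phenyl in place of butyl on an amide-type nitrogen. For the measured compounds named here, one measured step bears on this position: a 2.3-fold higher number from compound 1 to compound 2 (0.37 log units; beyond the scatter), which shows that the group on that urea nitrogen shifts the read-out beyond the scatter. Going by the values given here, compound 3, which carries an aryl urea but also differs elsewhere, gives the lowest number of the three; no single step connects it to compound 2, so it can only suggest a direction. A lower number for compound 4 than for compound 2 is therefore expected, with a step of moderate size, a 3.5-fold lower number from compound 2 to compound 4 (0.54 log units; beyond the scatter), because the change at this nitrogen moved the read-out by a 2.3-fold higher number from compound 1 to compound 2 (0.37 log units; beyond the scatter). Compound 4 is estimated at 900 nM, in the range 300 nM to 2700 nM.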

Compound 4, half-maximal inhibitory concentration: 2090 nM
Estimate against measurement, compound 4: 2.3-fold (0.37 log units) below; the measured number falls inside the stated range.
By their numbers in this assay, from the lowest: compound 3; then compounds 1, 4 and 2 (each within the scatter of the next, the first and the last beyond it).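

In this assay, 4-(trifluoromethyl)phenyl in place of butyl on this urea nitrogen gives a 1.5-fold lower number from compound 2 to compound 4 (0.17 log units; within the scatter), and in place of cyclohexyl it gives a 1.6-fold higher number from compound 1 to compound 4 (0.19 log units; within the scatter); both steps stay within the scatter. This aryl group therefore cannot be told apart from either alkyl group at this position, even though the two alkyl groups are separated by a 2.3-fold higher number from compound 1 to compound 2 (0.37 log units; beyond the scatter). No evidence is available here to explain this outcome.

Compound 3 differs from these compounds in more than one place, so the part played by its urea group cannot be separated from its other differences. Going by these compounds, it also remains open whether an unsubstituted phenyl, a phenyl bearing a carboxylic acid or a chain ending in an amine on this urea nitrogen would shift the read-out beyond the scatter.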